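The compounds below may be only part of what the source reports. "The series", "measured", "known", "first", "only" and "open" are said of these compounds alone.

Working notes on the series

Of the compounds shown here, three on the shared core have been measured in an assay for binding affinity to adenosine receptor A1 (Rattus norvegicus), read by radioligand binding; on this read-out higher numbers stand for weaker inhibition and lower numbers for stronger inhibition. Compound 1 `CCn1c(=O)c2nc(-c3cccc(S(=O)(=O)NCCN(C)C)c3)[nH]c2n(CC)c1=O` gives 553 nM. Compound 2 `CCn1c(=O)c2nc(-c3ccc(S(=O)(=O)N4CCOCC4)cc3)[nH]c2n(CC)c1=O` gives 310 nM and stands at the lowest number of the three; its nearest neighbour is compound 1, whose number is within the scatter of it, so no order between compound 2 and compound 1 can be read from these values. Compound 3 `CCn1c(=O)c2nc(-c3cccc(S(=O)(=O)O)c3)[nH]c2n(CC)c1=O` gives 30700 nM, far beyond the scatter from both. Among the measured compounds shown here, the single measured step that bears on the change under study is the one from compound 1 to compound 3, a 56-fold higher number from compound 1 to compound 3 (1.74 log units; beyond the scatter), which replaces the sulfonamide substituent with a hydroxy on the sulfonyl sulfur.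

Compound 4 `CCn1c(=O)c2nc(-c3ccc(S(=O)(=O)O)cc3)[nH]c2n(CC)c1=O` has not yet been measured. It differs from compound 2 by hydroxy in place of morpholin-4-yl on a sulfonyl sulfur. For the measured compounds named here, this is the same kind of replacement as the one from compound 1 to compound 3, made on a different sulfonamide and with the sulfonyl group on another position of the phenyl ring. One such step is known, so the expectation rests on it alone: a large rise in number is expected, in the direction of weaker inhibition, of about the size seen before. Compound 4 is therefore estimated to give 15000 nM in this assay, with a range from 4000 nM to 60000 nM. The expected step from compound 2 to compound 4 is a 48-fold higher number from compound 2 to compound 4 (1.68 log units; beyond the scatter).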

Compound 4, half-maximal inhibitory concentration: 5540 nM
Compound 4: middle estimate off by 2.7-fold (0.43 log units), on the high side; low and high end bracket the measured number.
By their numbers in this assay, from the lowest: compounds 2 and 1 (each within the scatter of the next); then compound 4; then compound 3.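

In this assay, the replacement of a sulfonamide substituent by hydroxy on a sulfonyl sulfur now has a second instance, an 18-fold higher number from compound 2 to compound 4 (1.25 log units; beyond the scatter), and it runs the same way as a 56-fold higher number from compound 1 to compound 3 (1.74 log units; beyond the scatter), so the direction holds for morpholin-4-yl as well as for (2-(dimethylamino)ethyl)amino, and no compound shown goes against it. The two starting sulfonamides lie within the scatter of each other, yet the two sulfo products do not share a number: compound 3 gives 30700 nM and compound 4 gives 5540 nM. The direction of the change therefore repeats across the two placements on the phenyl ring, while its size is not the same number in both pairs, and these two pairs differ both in the group that leaves and in that placement, so neither can be singled out for the difference in size.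

No available evidence accounts for the rise in number on this change. Still open, as far as these compounds go, is whether the step follows the entry of hydroxy or the departure of the amine part, which a plain amino group on the sulfonyl sulfur or a carboxylic acid in place of the sulfo group would help to separate.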